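The compounds below may be only part of what the source reports. "The series", "measured", "known", "first", "only" and "open" are said of these compounds alone.

Working notes on the shared core of compound 1 `O=C(Nc1cc(-c2ccccc2)nn1-c1ccccc1)c1ccc(F)c(F)c1`. In an assay on isolated protein with metabotropic glutamate receptor 5 (Rattus norvegicus) as the target (on this read-out lower numbers stand for an effect already at smaller amounts and higher numbers for an effect only at larger amounts of compound), compound 1 gives 20 nM. Compound 2 `O=C(Nc1cc(-c2ccccc2)nn1-c1ccccc1)c1ccccc1` gives 300 nM in this assay, and compound 3 `O=C(Nc1cc(-c2ccccc2)nn1-c1ccccc1)c1cnccn1` gives 400 nM, the highest of the three numbers; its nearest step is a 1.3-fold higher number from compound 2 to compound 3 (0.12 log units; within the scatter), its furthest a 20-fold higher number from compound 1 to compound 3 (1.30 log units; beyond the scatter). Compound 4 `O=C(Nc1cc(-c2ccccc2)nn1-c1ccccc1)c1ccccc1O` differs from compound 3 by 2-hydroxyphenyl in place of pyrazin-2-yl on a carbonyl carbon. Steps at this carbonyl carbon so far: a 15-fold higher number from compound 1 to compound 2 (1.18 log units; beyond the scatter) and a 20-fold higher number from compound 1 to compound 3 (1.30 log units; beyond the scatter), both large; a 1.3-fold higher number from compound 2 to compound 3 (0.12 log units; within the scatter), within the scatter. Compound 4 brings back a six-membered aromatic ring of carbon only, as in compound 2 with 300 nM, so no step beyond the scatter is expected. The expected step is a 1.6-fold lower number from compound 3 to compound 4 (0.20 log units; within the scatter). Compound 4 is estimated at 250 nM, range 60 nM to 1000 nM.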

Compound 4, half-maximal effective concentration: > 10000 nM
Compound 4 was reported as a limit (the forecaster's own chance of this, stated with the estimate: 5%); at least 40-fold (1.60 log units) between middle value and limit.
By their numbers in this assay, from the lowest: compound 1; then compounds 2 and 3 (each within the scatter of the next). At a limit, above all of these: compound 4.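

In this assay compound 4 gives only a limit and not a number: the limit of > 10000 nM in this assay, at which 1 of the 4 values shown sits. Hydroxy in place of hydrogen on an aromatic carbon alone gives an at least 33-fold higher number from compound 2 to compound 4 (1.52 log units; beyond the scatter), so this carbonyl carbon is sensitive to a single group on the ring, which the earlier steps did not show. The change also gives an at least 25-fold higher number from compound 3 to compound 4 (1.39 log units; beyond the scatter) and an at least 500-fold higher number from compound 1 to compound 4 (2.69 log units; beyond the scatter), so a carbon-only ring does not in itself keep a measurable value here.

Whether this follows from the hydroxy itself or from where it sits stays open, since the compounds shown do not separate the two. On these data alone, how 3-hydroxyphenyl, 4-hydroxyphenyl, 2-methoxyphenyl or 2-aminophenyl would read at this carbonyl carbon also stays open.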